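This account rests on a few compounds, and the source may have more. Where it says the series, first, only, none or still open, it means among the compounds named here.

Values in a functional assay on HCT-8 cells (Homo sapiens) for antiproliferative activity, read by MTT assay, with a stated time of 48 h; on this read-out higher numbers stand for weaker inhibition and lower numbers for stronger inhibition:
compound 1 `COc1ccc(C(=O)c2ccc3c(c2)C=CC(C)(C)O3)c(NC(=O)CO)c1` gives 250 nM
compound 2 `COc1ccc(C(=O)c2ccc3c(c2)C=CC(C)(C)O3)c(NC(=O)CN)c1` gives 490 nM
compound 3 `C=C(c1ccc2c(c1)C=CC(C)(C)O2)c1ccc(OC)cc1NC(=O)CO` gives 220 nM

Compound 1 and compound 3 differ in their cores; that difference is not broken down here. Compound 3 stands nearest compound 1, and the two values lie within the scatter of each other. On the core of compound 1 the change amino in place of hydroxy on a saturated chain carbon bound to a carbonyl carbon gave a 2.0-fold higher number from compound 1 to compound 2 (0.29 log units; within the scatter). Compound 4 `C=C(c1ccc2c(c1)C=CC(C)(C)O2)c1ccc(OC)cc1NC(=O)CN` carries the same change on the core of compound 3: amino in place of hydroxy on a saturated chain carbon bound to a carbonyl carbon. The place reads the same word for word in both cases, so this is the same change. Going by the values given here, for compound 4 the expected step is a 2.0-fold higher number from compound 3 to compound 4 (0.31 log units; beyond the scatter), because a 2.0-fold higher number from compound 1 to compound 2 (0.29 log units; within the scatter) is the only precedent, and it is a modest one. Compound 4 is therefore estimated at 450 nM in this assay, with a likely range from 250 nM to 850 nM.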

Compound 4, half-maximal inhibitory concentration: 220 nM
Compound 4: the middle estimate sits 2.0-fold (0.31 log units) above what was measured, and the stated range ends above it.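

In this assay, amino in place of hydroxy on a saturated chain carbon bound to a carbonyl carbon gave no change at the digits printed from compound 3 to compound 4 (within the scatter). Set beside the earlier step, the two cores do not separate for this change: the same change on two cores in this assay, a 2.0-fold higher number (0.29 log units; within the scatter) from compound 1 to compound 2 and no change at the digits printed (within the scatter) from compound 3 to compound 4, 2.0-fold (0.29 log units) apart, within the scatter of two such steps. This shows no dependence on the core beyond the scatter, but two pairs, each with a step within the scatter, cannot establish that the change carries over unaltered to further cores, or that it moves the value on either core.

Still open, going by these compounds, is how other groups would read on the same chain carbon, such as a dimethylamine, a carboxylic acid or a longer aminoethyl chain. Also open, on these data alone, is whether hydroxymethyl to aminomethyl behaves alike on cores beyond these two.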